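Fluoro on the benzyl group of compound 3

The source may report more compounds than this note shows. Statements on the series, on what has been measured and on what is new or still open speak of the compounds shown alone.

Measured in a functional assay on the whole organism (artery, strain albino) with Rattus norvegicus as the target, with a stated time of 900 min, at a dose of 10 mg/kg by the oral route; a lower number here means less inhibition, a higher number more inhibition at the dose given (going by the name of the read-out):
compound 1, `CC1=C(C(=O)Nc2ccc(F)cc2)C(c2ccc([N+](=O)[O-])cc2)N=C(SCc2ccccc2Cl)N1`: 11.3%
compound 2, `CC1=C(C(=O)Nc2ccc(Br)cc2)C(c2ccc(Cl)cc2Cl)N=C(SCc2ccccc2)N1`: 8.2%
compound 3, `COc1ccc(C2N=C(SCc3ccccc3)NC(C)=C2C(=O)Nc2ccc(Br)cc2)cc1`: 5.6%

Compound 3 gives the lowest of the three numbers, yet its distance to compound 2, a number 2.6 percentage points lower from compound 2 to compound 3 (within the scatter), and the gap to compound 1 both lie within the scatter, so the three compounds are not told apart here.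

Compound 4, `COc1ccc(C2N=C(SCc3ccc(F)cc3)NC(C)=C2C(=O)Nc2ccc(Br)cc2)cc1`, differs from compound 3 by fluoro in place of hydrogen on an aromatic carbon. No measured step in this assay carries the same change; the only step shown, from compound 2 to compound 3, concerns another part of the core. For compound 4 the step of a number 0.4 percentage points higher from compound 3 to compound 4 (within the scatter) is therefore expected to stay within the scatter. Compound 4 is estimated at 6%, with a range from -2% to 15%.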

Compound 4, a percentage reported as inhibition, in the whole organism at one dose (the size of the read-out at that dose, not a potency): 15.4%
For compound 4 the middle estimate is 9.4 percentage points below the measured one; the measured number lies above the stated range.
By their numbers in this assay, from the lowest: compounds 3, 2, 1 and 4 (each within the scatter of the next).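

In this assay, the step of a number 9.8 percentage points higher from compound 3 to compound 4 (within the scatter) is the only one here that isolates the benzyl group, with 4-fluorobenzyl in place of benzyl and the rest of compound 3 unchanged. On this step, fluoro in place of hydrogen at this position does not separate the two compounds, so no effect of this change can be claimed. Nothing available explains the size of this step.

Still open, going by these compounds, is whether an amine or a carboxylic acid on this aromatic ring would give a step beyond the scatter. Also open, on these data alone, is whether the fluoro step would read the same with a 2,4-dichlorophenyl group on the saturated ring carbon.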